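Ethyl ester in place of the phosphate ester

The compounds below may be only part of what the source reports. "The series", "measured", "known", "first", "only" and "open" are said of these compounds alone.

Compound 2 `CCOc1cc(NC(=O)C2(NC(=O)c3ccc4c(C5CCCC5)c(-c5ncc(Cl)cn5)n(C)c4c3)CCC2)ccc1/C=C/C(=O)OCOP(=O)(O)O`: 0.15 h
Compound 1 `CCOc1cc(NC(=O)C2(NC(=O)c3ccc4c(C5CCCC5)c(-c5ncc(Cl)cn5)n(C)c4c3)CCC2)ccc1/C=C/C(=O)OCOP(=O)(O)OC(C)(C)C`: 0.133 h

Both measured compounds share the same core and differ only at the phosphate oxygen. In an ADME assay (liver) for pharmacokinetics, with Liver microsome (Rattus norvegicus) as the target, using microsomes (a lower number here means that the compound disappears faster, a higher number that the compound lasts longer), compound 2 gives 0.15 h and stands highest of the two numbers, though compound 1 with 0.133 h lies within the scatter of it; the step of a 1.1-fold higher number from compound 1 to compound 2 (0.05 log units; within the scatter) is the only one known. Compound 3 `CCOC(=O)/C=C/c1ccc(NC(=O)C2(NC(=O)c3ccc4c(C5CCCC5)c(-c5ncc(Cl)cn5)n(C)c4c3)CCC2)cc1OCC` carries the change (one carbon atom in place of a group of 5 heavy atoms (4 oxygen, 1 phosphorus; no ring), on a saturated chain carbon bound to an oxygen next to a carbonyl group). Within the data shown here, no measured step touches this part of the molecule, so the one known step offers no guide beyond showing that a change at the phosphate end left the half-life where it was. Compound 3 is therefore expected to stay close to compound 2, with a 1.2-fold higher number from compound 2 to compound 3 (0.08 log units; within the scatter) and no step beyond the scatter foreseen. Compound 3 is estimated at 0.18 h in this assay, within 0.07 h to 0.5 h.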

Compound 3, half-life: 3.07 h
For compound 3 the middle estimate is 17-fold (1.23 log units) below the measured one, outside the stated range (above it).
By their numbers in this assay, from the lowest: compounds 1 and 2 (each within the scatter of the next); then compound 3.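

Where the change at the phosphate oxygen had left the number within the scatter, replacing the whole phosphate ester with an ethyl ester moves it far: in this assay the change gives a 20-fold higher number from compound 2 to compound 3 (1.31 log units; beyond the scatter), and with the tert-butyl still on the phosphate it gives a 23-fold higher number from compound 1 to compound 3 (1.36 log units; beyond the scatter). The two steps are of similar size, so in these compounds the outcome follows the presence or absence of the phosphate ester as a whole, whichever group sits on its oxygen. No measurement shown here bears on the reason for this large rise.

The compounds shown leave open whether the ethyl ester itself matters or any simple ester would serve at this place. A methyl ester, a longer chain on the ester oxygen or the free carboxylic acid would help to settle that.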